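A few compounds are considered here, and "the series" means these few. Any claim that something is new, unique, unknown or untested is made for them only; others in the source may bear on it.

The compounds with a result in a functional assay on HCT-116 cells (Homo sapiens) for inhibition, read by resazurin assay, with a stated time of 5 days (on this read-out higher numbers stand for weaker inhibition of growth and lower numbers for stronger inhibition of growth), are:
compound 1 `O=C(CCCC1CCN(S(=O)(=O)c2ccccc2Cl)CC1)NO`, 2800 nM;
compound 3 `O=C(CCCC1CCN(S(=O)(=O)c2cccc3ccccc23)CC1)NO`, 1040 nM.
Compound 2 `COc1ccc(S(=O)(=O)N2CCC(CCCC(=O)NO)CC2)c(OC)c1` has no result reported in this assay, where compound 2 stands as "not determined" (no result reported).

Among the two numbers, compound 1 stands highest in this assay with 2800 nM. Its nearest neighbour, compound 3, gives 1040 nM, a lower number, and the gap between the two lies beyond the usual scatter of repeated measurements. Going by the values given here, no pair of measured compounds differs in a single place, so no step between measured values can be drawn on.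

Compound 4 `O=C(CCCC1CCN(S(=O)(=O)Cc2ccccc2)CC1)NO` remains to be measured in this assay. It differs from compound 1 by benzyl in place of 2-chlorophenyl on a sulfonyl sulfur. Among the compounds with values here, nothing among the measured compounds shows the effect of this particular change, so the expectation rests on compound 1 alone. For compound 4 the step of a 1.1-fold higher number from compound 1 to compound 4 (0.03 log units; within the scatter) is expected to stay within the scatter, with no clear direction. Compound 4 is accordingly estimated at 3000 nM, within a range from 1000 nM to 9000 nM.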

Compound 4, concentration for 50% growth inhibition: 3200 nM
Compound 4: the middle estimate sits 1.1-fold (0.03 log units) below what was measured; measured number inside the range.
By their numbers in this assay, from the lowest: compound 3; then compounds 1 and 4 (each within the scatter of the next).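

In this assay, going by these compounds alone, benzyl in place of 2-chlorophenyl on a sulfonyl sulfur gives a 1.1-fold higher number from compound 1 to compound 4 (0.06 log units; within the scatter), the first single change at this position that can be read, and compound 1 and compound 4 cannot be told apart. At this position, then, the sulfonyl sulfur carries either group with no difference that the assay can resolve, although benzyl has seven carbon atoms and 2-chlorophenyl has six carbon atoms and one chlorine. No measurement at hand bears on why the two groups read alike.

The compounds shown leave open whether 2-phenylethyl, a longer chain in place of benzyl, or a benzyl carrying an amine or a carboxylic acid would stay level with compound 4. On these data alone, with no number for compound 2, the effect of methoxy groups on the aryl ring also remains open.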